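This account rests on a few compounds, and the source may have more. Where it says the series, first, only, none or still open, it means among the compounds named here.

Measured compounds:
Compound 1, `CCCCNc1nc(SCC)nc2ncccc12`, gives 20900 nM.
Compound 2, `CCCCCNc1nc(SCC)nc2ncccc12`, gives 4300 nM.
Compound 3, `CCCCCNc1nc(SCCCC)nc2ncccc12`, gives 8900 nM.

All three were tested in a functional assay on T-24 cells (Homo sapiens) for cytotoxicity, read by neutral red uptake, with a stated time of 72 h; on this read-out higher numbers stand for weaker inhibition and lower numbers for stronger inhibition. Compound 1 and compound 2 share a core and differ only in the chain on the ring nitrogen: methyl in place of hydrogen on a saturated chain carbon, four bonds along the chain from a nitrogen on an aromatic ring. That change made the step of a 4.9-fold lower number from compound 1 to compound 2 (0.69 log units; beyond the scatter). Compound 2 and compound 3 differ instead at the sulfur side, where an ethyl group replaces a hydrogen two bonds along the chain, and the step was a 2.1-fold higher number from compound 2 to compound 3 (0.32 log units; beyond the scatter). The difference between the core of compound 1 and the core of compound 3 is not broken down here.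

Compound 4, `CCCCCCNc1nc(SCCCC)nc2ncccc12`, has not yet been tested. It is related to compound 3 as compound 2 is to compound 1, by the same kind of change: methyl in place of hydrogen on a saturated chain carbon, five bonds along the chain from a nitrogen on an aromatic ring. The place is not identical, since the new methyl sits five bonds rather than four bonds along the chain from the nitrogen on the aromatic ring. Lengthening this chain gave a clear gain once, so compound 4 is expected to improve on compound 3, though by a smaller step than the earlier one, because the step of a 4.9-fold lower number from compound 1 to compound 2 (0.69 log units; beyond the scatter) rests on a single pair and further lengthening need not repeat it. The expected step is a 2.0-fold lower number from compound 3 to compound 4 (0.30 log units; within the scatter) in this assay. Compound 4 is estimated at 4500 nM, between 1500 nM and 13000 nM.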

Compound 4, half-maximal inhibitory concentration: 4500 nM
For compound 4 middle estimate and measured number coincide at the digits printed, and the stated range covers the measured number.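

In this assay, putting methyl in place of hydrogen on a saturated chain carbon, five bonds along the chain from a nitrogen on an aromatic ring, gives a 2.0-fold lower number from compound 3 to compound 4 (0.30 log units; within the scatter), and a step of this size does not by itself separate the two compounds. Set beside the earlier lengthening of the same chain, on a core with a different chain on the sulfur, the new step cannot be told apart from it: the same change on two cores in this assay, a 4.9-fold lower number (0.69 log units; beyond the scatter) from compound 1 to compound 2 and a 2.0-fold lower number (0.30 log units; within the scatter) from compound 3 to compound 4, 2.5-fold (0.39 log units) apart, within the scatter of two such steps. So the change carries from one core to the other without a size difference that can be read, and both steps point the same way, but this rests on just two steps, with the methyl at a different place along the chain in each, so it shows neither that the two steps are truly equal nor that the change would behave alike on any further core.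

The compounds shown leave open whether a longer chain on that nitrogen would keep moving the number the same way, or whether the trend would stop there. They also leave open what a chain carrying an amine or a carboxylic acid would do in place of these plain carbon chains, on either the nitrogen or the sulfur side.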